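Chlorine Position on the Benzyl Sulfide in Rat Artery

This account rests on a few compounds, and the source may have more. Where it says the series, first, only, none or still open, it means among the compounds named here.

Measured so far:
compound 1, `CC1=C(C(=O)Nc2ccc(F)cc2)C(c2ccc([N+](=O)[O-])cc2)N=C(SCc2cccc(Cl)c2)N1`: 9.8%
compound 2, `CC1=C(C(=O)Nc2ccc(F)cc2)C(c2ccc([N+](=O)[O-])cc2)N=C(SCc2ccc(Cl)cc2)N1`: 16%
compound 3, `COc1ccc(C2N=C(SCc3cccc(Cl)c3)NC(C)=C2C(=O)Nc2ccc(Br)cc2)cc1`: 21.1%

These three compounds were tested in a functional assay on the whole organism (artery, strain albino) with Rattus norvegicus as the target, with a stated time of 120 min, at a dose of 10 mg/kg by the oral route; a higher number here means more inhibition at the dose given (going by the name of the read-out), a lower number less inhibition. Compound 1 and compound 2 share one core and differ only by 4-chlorophenyl in place of 3-chlorophenyl on a saturated chain carbon bound to a sulfur, a change that gave a number 6.2 percentage points higher from compound 1 to compound 2 (within the scatter). Compound 3 rests on a different core; how its core differs from that of compound 1 is not broken down here. Compound 3 and compound 2 lie within the scatter of each other, while the gap between compound 3 and compound 1 lies beyond it.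

Compound 4, `COc1ccc(C2N=C(SCc3ccc(Cl)cc3)NC(C)=C2C(=O)Nc2ccc(Br)cc2)cc1`, has not yet been measured in this assay. It differs from compound 3 by 4-chlorophenyl in place of 3-chlorophenyl on a saturated chain carbon bound to a sulfur, the same change at the same place as between compound 1 and compound 2. Because that earlier change gave a number 6.2 percentage points higher from compound 1 to compound 2 (within the scatter), a step of similar size is expected in this assay, namely a number 4.9 percentage points higher from compound 3 to compound 4 (within the scatter). Compound 4 is therefore estimated at 26%, with an expected range from 12% to 40%.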

Compound 4, a percentage reported as inhibition, in the whole organism at one dose (the size of the read-out at that dose, not a potency): 16.5%
The estimate for compound 4 lay 9.5 percentage points above the measured number; the range from low to high includes it.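

In this assay, putting 4-chlorophenyl in place of 3-chlorophenyl on the saturated chain carbon bound to a sulfur gave a number 4.6 percentage points lower from compound 3 to compound 4 (within the scatter). Set beside the same change on the other core, this step cannot be told apart from the earlier one: the same change on two cores in this assay, a number 6.2 percentage points higher (within the scatter) from compound 1 to compound 2 and a number 4.6 percentage points lower (within the scatter) from compound 3 to compound 4, 10.8 percentage points apart, within the scatter of two such steps. The two steps therefore give no sign that the result of this change depends on the core, but they do not show that the two cores respond alike, and two steps are too few to settle it.

The compounds shown leave open how an amine or a carboxylic acid in place of the chlorine would read in this assay. Going by these compounds, a longer chain on the sulfur also remains open.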